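The source may hold more compounds than are shown below. What is called first, only, known or untested is meant among the compounds shown, and "the series" means these compounds.

Compound 1 `Cc1ccc(NC(=S)NC(=O)c2ccc(OCc3ccccc3F)cc2)cc1-c1nc2ccccc2[nH]1` is the starting point: in a functional assay on MNK45 cells (Homo sapiens) for inhibition, read by MTT assay, with a stated time of 48 h (a lower number here means a stronger inhibitor, a higher number a weaker inhibitor), compound 1 gives 2420 nM. Compound 2 `Cc1ccc(NC(=S)NC(=O)c2ccc(OCc3cccc(Cl)c3Cl)cc2)cc1-c1nc2ccccc2[nH]1` carries 2,3-dichlorophenyl in place of 2-fluorophenyl on a saturated chain carbon bound to an oxygen on an aromatic ring. In this assay compound 2 returns only a limit of the assay, > 100000 nM. The step of an at least 41-fold higher number from compound 1 to compound 2 (1.61 log units; beyond the scatter) is thus read against (the limit of > 100000 nM in this assay, at which 1 of the 3 values shown sits), so its true size is not pinned down. Compound 3 `Cc1ccc(NC(=O)NC(=O)c2ccc(OCc3ccccc3F)cc2)cc1-c1nc2ccccc2[nH]1` rests on a different core; the difference between the core of compound 3 and the core of compound 1 is not broken down here. In this assay compound 3 gives 1830 nM, and compound 1 lies within the scatter of that number, so no order between the two is claimed. Compound 4 `Cc1ccc(NC(=O)NC(=O)c2ccc(OCc3cccc(Cl)c3Cl)cc2)cc1-c1nc2ccccc2[nH]1` carries 2,3-dichlorophenyl in place of 2-fluorophenyl on a saturated chain carbon bound to an oxygen on an aromatic ring, the same change at the same place as that between compound 1 and compound 2. Since the earlier step of an at least 41-fold higher number from compound 1 to compound 2 (1.61 log units; beyond the scatter) was large, compound 4 is expected to lose potency by about a 33-fold higher number from compound 3 to compound 4 (1.52 log units; beyond the scatter). The estimate for compound 4 is 60000 nM, spanning 8000 nM to 150000 nM, with a real chance that only a limit is reported.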

Compound 4, half-maximal inhibitory concentration: 87000 nM
Compound 4: middle estimate off by 1.5-fold (0.16 log units), on the low side; low and high end bracket the measured number.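

Putting 2,3-dichlorophenyl in place of 2-fluorophenyl on the second core gives a 48-fold higher number from compound 3 to compound 4 (1.68 log units; beyond the scatter) in this assay, so the change is large on this core too. Across these two cores the direction of the change carries over, but how closely its size carries over is not shown: the same change on two cores in this assay, an at least 41-fold higher number (1.61 log units; beyond the scatter) from compound 1 to compound 2 and a 48-fold higher number (1.68 log units; beyond the scatter) from compound 3 to compound 4; the limit leaves it open whether they differ Compound 2 has only a limit of the assay, and two cores are too few to predict what the change would do elsewhere in the series: the limit of > 100000 nM in this assay, at which 1 of the 4 values shown sits.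

The compounds shown leave open whether the loss needs both chlorines, since a phenyl ring with a single chlorine, or one with a methoxy group, does not appear among them. Going by these compounds, it also remains open how an amine or a carboxylic acid on that ring would read in this assay, and whether the same large step would return on a third core.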